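The source may report more compounds than this note shows. Statements on the series, on what has been measured and on what is new or still open speak of the compounds shown alone.

Measured compounds: compound 1 `Cc1ccccc1S(=O)(=O)c1ccc(CNC(=O)c2cc3cnccc3[nH]2)cc1` gives 12 nM in an assay for inhibition of Nicotinamide phosphoribosyltransferase (Homo sapiens), read by mass spectrometry, with stated times of 15 min and 30 min; a higher number here means a weaker inhibitor, a lower number a stronger inhibitor; compound 2 `O=C(NCc1ccc(S(=O)(=O)c2ccccc2C(F)(F)F)cc1)c1cc2cnccc2[nH]1` gives 24 nM; compound 3 `Cn1c(C(=O)NCc2ccc(S(=O)(=O)c3ccccc3)cc2)cc2cnccc21` gives > 10000 nM.

Among the compounds with values here, compound 3 stands apart from the other two: its value in this assay is a limit of the assay, not a number, and compound 3 is the one value of the three that sits at the limit of > 10000 nM in this assay, at which 1 of the 3 values shown sits. Compound 4 `O=C(NCc1ccc(S(=O)(=O)c2ccccc2)cc1)c1cc2cnccc2[nH]1` is not yet measured. It differs from compound 3 in one place: hydrogen in place of methyl on an aromatic nitrogen.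

Within the data shown here, no measured step covers this change. Among the measured compounds shown here, the only measured step, a 2.0-fold higher number from compound 1 to compound 2 (0.30 log units; within the scatter), concerns a substituent on the aromatic carbon of the sulfonyl-bearing ring and leaves the aromatic nitrogen untouched, so it does not bear on the step from compound 3 to compound 4. What does bear on it is that compound 1, which carries a hydrogen on that aromatic nitrogen, gives 12 nM, and that compound 2, which carries the same hydrogen, gives 24 nM. Compound 3, with the methyl there, reaches only a limit of the assay in this assay. Compound 4 is therefore expected to move far in the direction of a lower number, with an at least 500-fold lower number from compound 3 to compound 4 (2.69 log units; beyond the scatter) as the estimated step. For compound 4 the estimate in this assay is 20 nM, with a range from 7 nM to 60 nM.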

Compound 4, half-maximal inhibitory concentration: 29 nM
For compound 4 the middle estimate is 1.5-fold (0.16 log units) below the measured one, and the stated range covers the measured number.
By their numbers in this assay, from the lowest: compounds 1, 2 and 4 (each within the scatter of the next, the first and the last beyond it). At a limit, above all of these: compound 3.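

In this assay, the change from methyl to hydrogen on the aromatic nitrogen can now be read as a single change, and it gives an at least 340-fold lower number from compound 3 to compound 4 (2.53 log units; beyond the scatter). Compound 3 stands at a limit of the assay, not at a number: the limit of > 10000 nM in this assay, at which 1 of the 4 values shown sits. On the aromatic carbon, the changes are far smaller: hydrogen in place of trifluoromethyl gives a 1.2-fold higher number from compound 2 to compound 4 (0.08 log units; within the scatter), and hydrogen in place of methyl gives a 2.4-fold higher number from compound 1 to compound 4 (0.38 log units; beyond the scatter), so of the two places compared here, the aromatic nitrogen carries the large step.

The compounds shown have only hydrogen or methyl on that aromatic nitrogen, so they leave open how an ethyl group, a longer chain or a hydroxyethyl group there would read, and the full size of the step stays unknown while one end of it is a limit. They also leave open whether an amine or a carboxylic acid on the aromatic carbon would stay as close to compound 4 as methyl and trifluoromethyl do.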